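This account rests on a few compounds, and the source may have more. Where it says the series, first, only, none or still open, it means among the compounds named here.

Among the measured compounds shown here, compound 3 `COC(=O)NC[C@H]1CN(c2ccc(-n3cc(-c4ccccn4)cn3)c(F)c2)C(=O)O1` gives the only number in the set: in an ADME assay on HEK293-A cells (Homo sapiens) for cytotoxicity, read by MTT assay, with a stated time of 48 h (a lower number here means a stronger inhibitor, a higher number a weaker inhibitor), compound 3 gives 306 ug/mL. Compound 1 `O=C(OC[C@H]1CN(c2ccc(-n3cc(-c4ccccn4)cn3)c(F)c2)C(=O)O1)c1ccccc1` reaches only the limit of the method, giving > 400 ug/mL. Compound 2 `O=C1O[C@@H](Cn2ccnc2)CN1c1ccc(-n2cc(-c3ccccn3)cn2)c(F)c1` likewise reaches only the limit, giving > 400 ug/mL. The step from compound 1 to compound 2 is therefore a step that the two limits leave unreadable from compound 1 to compound 2, while the other two steps, an at least 1.3-fold lower number from compound 1 to compound 3 (0.11 log units; that floor lies within the scatter) and an at least 1.3-fold lower number from compound 2 to compound 3 (0.11 log units; that floor lies within the scatter), are floors that lie within the scatter; two of the three values sit at the limit of > 400 ug/mL in this assay, at which 2 of the 3 values shown sit.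

Compound 4 `O=C(NC[C@H]1CN(c2ccc(-n3cc(-c4ccccn4)cn3)c(F)c2)C(=O)O1)C(F)F` differs from compound 3 by difluoromethyl in place of methoxy on a carbonyl carbon. For the measured compounds named here, none of the measured steps touches that carbonyl carbon; all three alter the group on the saturated chain carbon, and none of them shows a movement beyond the scatter. He therefore expects no step beyond the scatter from compound 3 to compound 4 in this assay, that is a 1.1-fold higher number from compound 3 to compound 4 (0.03 log units; within the scatter). His estimate for compound 4 is 330 ug/mL, with a range from 160 ug/mL to 480 ug/mL, and a fair chance that only a limit is reported.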

Compound 4, half-maximal inhibitory concentration: 167 ug/mL
Compound 4: the middle estimate sits 2.0-fold (0.30 log units) above what was measured, and the stated range covers the measured number.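

In this assay, among the compounds shown here, the carbonyl carbon is changed for the first time, and difluoromethyl in place of methoxy there gives a 1.8-fold lower number from compound 3 to compound 4 (0.26 log units; within the scatter), so this change does not separate the two compounds. For the compounds shown here, on the saturated chain carbon, ((difluoromethyl)carbonyl)amino gives the first steps in the set that pass beyond the scatter: an at least 2.3-fold lower number from compound 2 to compound 4 (0.37 log units; beyond the scatter) in place of 1H-imidazol-1-yl, and an at least 2.3-fold lower number from compound 1 to compound 4 (0.37 log units; beyond the scatter) in place of benzoyloxy. Both steps are only floors, because compound 1 and compound 2 each stand at a limit of the method rather than at a number: the limit of > 400 ug/mL in this assay, at which 2 of the 4 values shown sit.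

From the compounds shown here alone, the true size of these two steps stays open. The compounds shown also leave open how the number would respond to an amine or a longer alkyl chain on that carbonyl carbon.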